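The source may hold more compounds than are shown below. What is called first, only, known or untested is meant among the compounds shown, and "the series" means these compounds.

Measured compounds:
compound 1 `COc1cc(-c2nn(-c3cccc(NC(=O)Nc4ccc(Cl)c(Cl)c4)c3)cc2-c2ccncc2)ccc1Cl` gives 1350 nM
compound 2 `O=C(Nc1cccc(-n2cc(-c3ccncc3)c(-c3ccc(Cl)c(O)c3)n2)c1)Nc1ccc(Cl)c(Cl)c1` gives 1510 nM

In a functional assay on NCI-H226 cells (Homo sapiens) for inhibition, read by sulforhodamine B assay, with a stated time of 48 h (a lower number here means a stronger inhibitor of growth, a higher number a weaker inhibitor of growth), compound 2 gives 1510 nM, and compound 1 gives 1350 nM; the two numbers stand within the usual scatter of each other, as the step of a 1.1-fold higher number from compound 1 to compound 2 (0.05 log units; within the scatter) shows, so neither compound can be set above the other. Compound 3 `O=C(Nc1cccc(-n2cc(-c3ccncc3)c(-c3ccc(Cl)c(O)c3)n2)c1)Nc1ccc(Cl)c(C(F)(F)F)c1` differs from compound 2 by trifluoromethyl in place of chloro on an aromatic carbon. For the measured compounds named here, the only measured step here concerns a different place, the oxygen on an aromatic ring, and so does not bear on this change; no measured step tests a trifluoromethyl in place of a chloro on the urea-bearing ring. With nothing to build on, the expected step from compound 2 to compound 3 is none beyond the scatter, that is a 1.0-fold lower number from compound 2 to compound 3 (0.00 log units; within the scatter). Compound 3 is therefore estimated at 1500 nM in this assay, with a range from 600 nM to 3800 nM.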

Compound 3, concentration for 50% growth inhibition: 1350 nM
Compound 3: the middle estimate sits 1.1-fold (0.05 log units) above what was measured; measured number inside the range.
By their numbers in this assay, from the lowest: compounds 1, 3 and 2 (each within the scatter of the next).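

Compound 1 and compound 2 differ only at the oxygen on an aromatic ring, so this is the only step shown that touches the other end of the urea: in this assay, replacing 3,4-dichlorophenyl with 4-chloro-3-(trifluoromethyl)phenyl gives a 1.1-fold lower number from compound 2 to compound 3 (0.05 log units; within the scatter). At this aromatic carbon, ortho to a chloro group, trifluoromethyl therefore stands in place of chloro with no step beyond the scatter. Nothing available explains this result.

On these data alone, it remains open whether an amine or a carboxylic acid on this carbon would shift the number beyond the scatter. As far as these compounds go, it is also open whether trifluoromethyl in place of chloro would give a similar step with the methyl on the oxygen, as in compound 1.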